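Methoxy to Ethoxy on Two Cores in an Aorta Assay

The compounds below may be only part of what the source reports. "The series", "measured", "known", "first", "only" and "open" are said of these compounds alone.

Of the compounds shown here, three have been measured in a functional assay on aorta (strain Wistar) for inhibition, with Thoracic aorta (Rattus norvegicus) as the target; on this read-out higher numbers stand for weaker inhibition and lower numbers for stronger inhibition. Compound 1 `COc1ccc(OC)c(-c2cc(-c3cc4ccccc4o3)nc(OC)c2C#N)c1` gives 246000 nM. Compound 2 `CCOc1nc(-c2cc3ccccc3o2)cc(-c2cc(OC)ccc2OC)c1C#N` differs from it by methyl in place of hydrogen on a saturated chain carbon bound to an oxygen on an aromatic ring, and in this assay compound 2 gives 327000 nM; the step is a 1.3-fold higher number from compound 1 to compound 2 (0.12 log units; within the scatter). Compound 3 `COc1nc(-c2cc3ccccc3o2)cc(-c2cccs2)c1C#N` carries a different core; the difference between the two cores is not broken down here. In this assay compound 3 gives 163000 nM, a number within the scatter of the other two.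

Compound 4 `CCOc1nc(-c2cc3ccccc3o2)cc(-c2cccs2)c1C#N` is not yet measured. It differs from compound 3 by methyl in place of hydrogen on a saturated chain carbon bound to an oxygen on an aromatic ring, the same kind of change as from compound 1 to compound 2, made here on the second core. Because that change gave a 1.3-fold higher number from compound 1 to compound 2 (0.12 log units; within the scatter), a step of similar size is expected here, resting on compound 3 and its 163000 nM. The step expected is a 1.3-fold higher number from compound 3 to compound 4 (0.11 log units; within the scatter). Compound 4 is expected to give 210000 nM, with a range from 100000 nM to 450000 nM.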

Compound 4, half-maximal inhibitory concentration: 308000 nM
Compound 4: middle estimate off by 1.5-fold (0.17 log units), on the low side, within the range that was stated.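

Changing methoxy to ethoxy on the core of compound 3 gives a 1.9-fold higher number from compound 3 to compound 4 (0.28 log units; within the scatter) in this assay, and the two steps for this change agree: the same change on two cores in this assay, a 1.3-fold higher number (0.12 log units; within the scatter) from compound 1 to compound 2 and a 1.9-fold higher number (0.28 log units; within the scatter) from compound 3 to compound 4, 1.4-fold (0.15 log units) apart, within the scatter of two such steps With the ethoxy group held constant, thiophen-2-yl in place of 2,5-dimethoxyphenyl gives a 1.1-fold lower number from compound 2 to compound 4 (0.03 log units; within the scatter), so this swap also yields a step that cannot be told from repeat-measurement noise. Among these compounds, the agreement therefore means only that neither core shows a step standing out from the scatter; it does not show that ethoxy truly changes inhibition in this assay, nor that the same result would hold on a third core.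

The compounds shown stop at methoxy and ethoxy, so a longer chain such as propyl or butyl, a branched isopropyl group, or an amine in that place remains open. Nothing here shows whether any of these groups would move the number beyond the scatter.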